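Acylation of the ring amine: from compound 3 to compound 4

This account rests on a few compounds, and the source may have more. Where it says the series, first, only, none or still open, it means among the compounds named here.

Measured compounds in a functional assay on HCT-116 cells (Homo sapiens) for antiproliferative activity, read by MTT assay, with a stated time of 72 h; a lower number here means a stronger inhibitor, a higher number a weaker inhibitor:
Compound 1, `COc1c(NS(=O)(=O)c2ccc(F)cc2)cc(-c2ccn3nc(NC(C)=O)nc3c2)cc1C(N)=O`, gives 32600 nM.
Compound 2, `COc1c(NS(=O)(=O)c2ccc(F)cc2)cc(-c2ccc3nc(NC(=O)C4CC4)nn3c2)cc1C(N)=O`, gives 43500 nM.
Compound 3, `COc1c(NS(=O)(=O)c2ccc(F)cc2)cc(-c2ccn3nc(N)nc3c2)cc1C(N)=O`, gives > 50000 nM, which is a limit of the assay and not a number.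

Compound 3 therefore stands at the edge of what this assay can report; it is the one of the three whose value is only a limit (the limit of > 50000 nM in this assay, at which 1 of the 3 values shown sits). Compound 4, `COc1c(NS(=O)(=O)c2ccc(F)cc2)cc(-c2ccn3nc(NC(=O)C4CC4)nc3c2)cc1C(N)=O`, carries cyclopropylcarbonyl in place of hydrogen on a nitrogen on an aromatic ring.

Within the data shown here, one measured step bears on this change. Going an at least 1.5-fold higher number from compound 1 to compound 3 (0.18 log units; that floor lies within the scatter), the removal of the acyl group moved the number upward to the limit; the floor of that step lies within the scatter, so its true size is unknown. Compound 2, which carries the same cyclopropylcarbonyl group on a differently arranged core, gives 43500 nM in this assay, a number in the same region as compound 1.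

Restoring an acyl group on the nitrogen is expected to reverse the direction seen from compound 1 to compound 3, bringing compound 4 back to a measurable number close to compound 1, with an at least 1.4-fold lower number from compound 3 to compound 4 (0.15 log units; that floor lies within the scatter) as the expected step. Compound 4 is estimated at 35000 nM, in the range 15000 nM to 70000 nM.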

Compound 4, half-maximal inhibitory concentration: > 50000 nM
Compound 4: no number, only a limit; the forecaster's own chance of this, stated with the estimate: 25%; at least 1.4-fold (0.15 log units) between middle value and limit.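

In this assay compound 4 gives > 50000 nM, which is a limit of the assay and not a number. Compound 3 also has only a limit, so the step between these two compounds cannot be read, and the result gives no size for cyclopropylcarbonyl in place of hydrogen on this nitrogen; it does show that an acyl group here need not bring the number back within the range this assay can report. Cyclopropyl in place of methyl on the carbonyl carbon gives an at least 1.5-fold higher number from compound 1 to compound 4 (0.18 log units; that floor lies within the scatter), so this pair does not separate the two acyl groups, even though only the acetyl compound has a measured number.

As far as these compounds go, how far the true values of compound 3 and compound 4 lie beyond the reported range stays open, and these two compounds cannot be placed in order: the limit of > 50000 nM in this assay, at which 2 of the 4 values shown sit. Also open is whether a longer chain on the carbonyl carbon, or an acyl group carrying an amine or a carboxylic acid, would give a number clearly beyond the scatter from that of compound 1.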